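From pyrrolidin-1-yl to ethyl(methyl)amino on a thiocarbonyl carbon

A few compounds are considered here, and "the series" means these few. Any claim that something is new, unique, unknown or untested is made for them only; others in the source may bear on it.

Measured so far in a toxicity assay on HeLa cells (Homo sapiens) for cytotoxicity, read by MTT assay, with a stated time of 24 h; a lower number here means a stronger inhibitor, a higher number a weaker inhibitor:

- compound 1 `Cc1ncc([N+](=O)[O-])n1CC(O)CSC(=S)N1CCN(c2ccccn2)CC1`: 2970000 nM
- compound 2 `Cc1ncc([N+](=O)[O-])n1CC(O)CSC(=S)N1CCN(c2ncccn2)CC1`: 2040000 nM
- compound 3 `Cc1ncc([N+](=O)[O-])n1CC(O)CSC(=S)N1CCCC1`: 1340000 nM

The value of compound 3 lies within the scatter of that of compound 2, and its number is lower than that of compound 1 by a margin beyond the scatter. Compound 4 `CCN(C)C(=S)SCC(O)Cn1c([N+](=O)[O-])cnc1C` departs from compound 3 as follows: ethyl(methyl)amino in place of pyrrolidin-1-yl on a thiocarbonyl carbon. It carries ethyl(methyl)amino in place of pyrrolidin-1-yl on a thiocarbonyl carbon.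

For the measured compounds named here, no measured step covers this exchange directly. Going by the values given here, the nearest evidence is the one measured step, a 1.5-fold lower number from compound 1 to compound 2 (0.16 log units; within the scatter), which stays within the scatter. Compounds 1, 2 and 3 also differ in the group on the thiocarbonyl carbon, yet their values stay close together in this assay. No step beyond the scatter is therefore expected. The estimated step is a 1.1-fold higher number from compound 3 to compound 4 (0.05 log units; within the scatter). For compound 4 the expected value is 1500000 nM, with an estimated range of 800000 nM to 2900000 nM.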

Compound 4, half-maximal inhibitory concentration: 4150000 nM
The estimate for compound 4 lay 2.8-fold (0.44 log units) below the measured number; measured number above the stated range.
By their numbers in this assay, from the lowest: compounds 3, 2, 1 and 4 (each within the scatter of the next, the first and the last beyond it).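

In this assay, for the compounds shown here, putting ethyl(methyl)amino in place of pyrrolidin-1-yl on a thiocarbonyl carbon gives a step beyond the scatter (a 3.1-fold higher number from compound 3 to compound 4 (0.49 log units; beyond the scatter)), so this position is sensitive to the exchange in a way the one earlier step between compounds differing in one place could not show. The exchange opens up the five-membered non-aromatic ring and goes from 5 heavy atoms to 4, while the count of hydrogen-bond donors and acceptors stays at 0 on both sides. No measurement here accounts for the rise in the number.

From the compounds shown here alone, what remains open is whether the step follows the loss of the ring or the change in the groups on the nitrogen. A diethylamino group, a dimethylamino group or a piperidin-1-yl ring at this place would help to separate these two readings.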